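The source may report more compounds than this note shows. Statements on the series, on what has been measured and on what is new or still open speak of the compounds shown alone.

Measured so far in an assay on microsomes from intestine for inhibition of acyl-CoA:cholesterol acyltransferase (Oryctolagus cuniculus); on this read-out higher numbers stand for weaker inhibition and lower numbers for stronger inhibition: compound 1 `CCCCCCCC/C=C/CCCCCCC(C)C(=O)Nc1c(OC)cc(OC)cc1OC` gives 36 nM; compound 2 `CCCCCCCC/C=C/CCCCCCC(C)(C)C(=O)Nc1c(OC)cc(OC)cc1OC` gives 44 nM.

Compound 2 holds the highest of the two numbers; its nearest neighbour is compound 1, and the step of a 1.2-fold higher number from compound 1 to compound 2 (0.09 log units; within the scatter) lies within the scatter, so the two compounds cannot be ordered.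

Compound 3 `CCCCCCCC(C)(C)C(=O)Nc1c(OC)cc(OC)cc1OC` differs from compound 2 by one carbon atom in place of a group of 10 heavy atoms (10 carbon; no ring), on a saturated chain carbon, seven bonds along the chain from a carbonyl carbon. For the measured compounds named here, no measured step touches this part of the chain; the only measured step concerns a methyl on the carbon bound to the carbonyl carbon and was within the scatter. The change is far larger than that, so the expectation rests on little, and a step beyond the scatter toward weaker inhibition, a 14-fold higher number from compound 2 to compound 3 (1.13 log units; beyond the scatter), is expected. For compound 3 the estimate in this assay is 600 nM, with a range from 100 nM to 5000 nM.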

Compound 3, half-maximal inhibitory concentration: 180 nM
Compound 3: middle estimate off by 3.3-fold (0.52 log units), on the high side, and the stated range covers the measured number.
By their numbers in this assay, from the lowest: compounds 1 and 2 (each within the scatter of the next); then compound 3.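

In this assay, methyl in place of the group of 10 heavy atoms, seven bonds along the chain from a carbonyl carbon, gives a 4.1-fold higher number from compound 2 to compound 3 (0.61 log units; beyond the scatter). This part of the chain therefore matters for inhibition, whereas the earlier methyl step on the carbon bound to the carbonyl carbon stayed within the scatter. No measurement at hand offers an explanation for this step.

The departing group holds the double bond and most of the chain length, and the compounds shown do not separate the two. A saturated chain of the same length as in compound 2 would bear directly on that question.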